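Aryl in place of benzyl on a thiazole-fused bromoacrylamide

This account rests on a few compounds, and the source may have more. Where it says the series, first, only, none or still open, it means among the compounds named here.

Measured compounds:
compound 1, `COc1ccc(-c2nn3cc(-c4cccc(N)c4)nc3s2)cc1OC`: 26000 nM
compound 2, `C=C(Br)C(=O)Nc1cccc(-c2cn3nc(Cc4cccc(OC)c4)sc3n2)c1`: 2500 nM
compound 3, `COc1cccc(Cc2nn3cc(-c4cccc(N)c4)nc3s2)c1`: 24000 nM

In a functional assay on HeLa cells (Homo sapiens) for inhibition, read by cell counting, with a stated time of 4 days (a lower number here means a stronger inhibitor, a higher number a weaker inhibitor), compound 2 gives the lowest number of the three. Its nearest neighbour is compound 3 with 24000 nM, and the gap a 9.6-fold higher number from compound 2 to compound 3 (0.98 log units; beyond the scatter) arises from a single change, hydrogen in place of (1-bromoethenyl)carbonyl on a nitrogen on an aromatic ring. Compound 1 sits furthest away.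

Compound 4, `C=C(Br)C(=O)Nc1cccc(-c2cn3nc(-c4ccc(CC)cc4)sc3n2)c1`, keeps the (1-bromoethenyl)carbonyl group of compound 2 and alters the other end: 4-ethylphenyl in place of 3-methoxybenzyl on an aromatic carbon

For the measured compounds named here, no measured step covers this exact exchange. The closest hint comes from compound 1 and compound 3, which share the free amine and differ only in whether an aryl ring or a benzyl group sits on the shared core; their numbers in this assay lie within the scatter of each other. Going by the values given here, that pair suggests that swapping 3-methoxybenzyl for 4-ethylphenyl changes little, though it is one comparison and carries no step of its own. The expectation is therefore a step of a 1.2-fold higher number from compound 2 to compound 4 (0.08 log units; within the scatter) that stays near the scatter in either direction. Compound 4 is estimated at 3000 nM, within 1000 nM to 9000 nM.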

Compound 4, half-maximal inhibitory concentration: 3200 nM
For compound 4 the middle estimate is 1.1-fold (0.03 log units) below the measured one, within the range that was stated.
By their numbers in this assay, from the lowest: compounds 2 and 4 (each within the scatter of the next); then compounds 3 and 1 (each within the scatter of the next).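

With the (1-bromoethenyl)carbonyl group in place, this aromatic carbon of the five-membered ring accepts 4-ethylphenyl for 3-methoxybenzyl with a 1.3-fold higher number from compound 2 to compound 4 (0.11 log units; within the scatter) in this assay. The earlier compounds shown here offered only a free-amine pair at this carbon, where compound 1 gives 26000 nM and compound 3 gives 24000 nM; the new step shows the same absence of a measurable shift that carries the (1-bromoethenyl)carbonyl group, even though the hydrogen-bond acceptor counted in 3-methoxybenzyl is missing from 4-ethylphenyl. No evidence is at hand that would explain this result.

The compounds shown leave open whether a carboxylic acid or an amine on the aromatic ring at this carbon, or a longer chain in place of the ethyl group, would hold the number as closely as these two groups do. For the compounds shown here, they also leave open whether a 4-ethylphenyl compound with the free amine would repeat a 9.6-fold higher number from compound 2 to compound 3 (0.98 log units; beyond the scatter), which is so far the only reading of what the (1-bromoethenyl)carbonyl group contributes.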